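Methyl added to the anilino ring: compound 4 from compound 2

A few compounds are considered here, and "the series" means these few. Any claim that something is new, unique, unknown or untested is made for them only; others in the source may bear on it.

In a functional assay on HGC-27 cells (Homo sapiens) for cytotoxicity, read by MTT assay, with a stated time of 72 h (on this read-out lower numbers stand for stronger inhibition and higher numbers for weaker inhibition), compound 2 `FC(F)(F)c1ccc(CSc2nc(Nc3ccccc3)c3ccccc3n2)cc1` gives 26400 nM, the second highest of the three numbers measured. Compound 1 `CCCCCCCCNc1nc(SCc2ccc(C(F)(F)F)cc2)nc2ccccc12` gives 13400 nM and compound 3 `Cc1ccccc1Nc1nc(SCc2ccc(C(F)(F)F)cc2)nc2ccccc12` gives 27500 nM; the step of a 2.0-fold higher number from compound 1 to compound 2 (0.29 log units; within the scatter) lies within the scatter, while a 2.1-fold higher number from compound 1 to compound 3 (0.31 log units; beyond the scatter) is modest. Compound 4 `Cc1ccc(Nc2nc(SCc3ccc(C(F)(F)F)cc3)nc3ccccc23)cc1` differs from compound 2 by methyl in place of hydrogen on an aromatic carbon. For the measured compounds named here, the one measured step of the same kind, a 1.0-fold higher number from compound 2 to compound 3 (0.02 log units; within the scatter), was flat, and the whole series spans little, so no step beyond the scatter is expected in this assay in either direction. Compound 4 is therefore estimated at 26000 nM, with a range of 12000 nM to 55000 nM. The step this estimate means is a 1.0-fold lower number from compound 2 to compound 4 (0.01 log units; within the scatter).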

Compound 4, half-maximal inhibitory concentration: 34600 nM
Estimate against measurement, compound 4: 1.3-fold (0.12 log units) below; low and high end bracket the measured number.
By their numbers in this assay, from the lowest: compounds 1, 2, 3 and 4 (each within the scatter of the next, the first and the last beyond it).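

In this assay, a methyl para to a large group on the anilino ring gives no readable change: a 1.3-fold higher number from compound 2 to compound 4 (0.12 log units; within the scatter) and, against the 2-methylphenyl, a 1.3-fold higher number from compound 3 to compound 4 (0.10 log units; within the scatter); neither methyl placement separates from the unsubstituted phenyl. Replacing octyl with an aryl group remains a modest loss for the methylated rings, with a 2.6-fold higher number from compound 1 to compound 4 (0.41 log units; beyond the scatter) joining the step to compound 3 beyond the scatter, while the step to compound 2 lies within it. No evidence on the cause of these results is available. Going by these compounds, whether an amine or a carboxylic acid at the same ring carbon would move the number beyond the scatter remains open.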